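The source may hold more compounds than are shown below. What is called first, only, known or untested is meant among the compounds shown, and "the series" means these compounds.

In a physicochemical assay, with a stated time of 90 min (on this read-out higher numbers stand for an effect only at larger amounts of compound and lower numbers for an effect already at smaller amounts), compound 1 `C/C(=N/N=C1\SCC(=O)N1Cc1ccc(F)cc1)c1ccccn1` gives 1160000 nM and compound 2 `C/C(=N\N=C1/SCC(=O)N1Cc1cccc(Cl)c1)c1ccccn1` gives 2040000 nM. Going by the values given here, these are the only two numbers so far, and they lie within the usual scatter of each other, so compound 1 cannot be ranked against compound 2.

Compound 3 `C/C(=N/N=C1\SCC(=O)N1Cc1ccc(F)cc1)c1cccs1` keeps the rest of compound 1 but carries thiophen-2-yl in place of pyridin-2-yl on a carbon with a double bond to nitrogen. Among the compounds with values here, no pair of measured compounds shows a swap of this kind, so the data offer no firm direction for it in this assay. The estimated step, a 1.3-fold higher number from compound 1 to compound 3 (0.11 log units; within the scatter), is therefore expected to stay within the scatter, and the wide range reflects how little is known. For compound 3 the estimated value is 1500000 nM, with an expected range from 500000 nM to 4500000 nM.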

Compound 3, half-maximal effective concentration: 1370000 nM
For compound 3 the middle estimate is 1.1-fold (0.04 log units) above the measured one, within the range that was stated.
By their numbers in this assay, from the lowest: compounds 1, 3 and 2 (each within the scatter of the next).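

Going by these compounds alone, compound 1 and compound 3 are the first measured pair that differ in one place, and in this assay putting thiophen-2-yl in place of pyridin-2-yl on a carbon with a double bond to nitrogen gives a 1.2-fold higher number from compound 1 to compound 3 (0.07 log units; within the scatter) and so leaves the two numbers within the usual scatter of each other. At this place, then, a six-membered aromatic ring carrying nitrogen and a five-membered aromatic ring carrying sulfur cannot be told apart on this read-out. The available data offer no measured explanation for this result. From the compounds shown here alone, what stays open is whether a plain phenyl ring, a carboxylic acid or an amine at this place would move the number beyond the scatter. A single swap also cannot show how far this result extends to other aromatic rings.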